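Adding One Fluoro to Compound 2

The source may report more compounds than this note shows. Statements on the series, on what has been measured and on what is new or still open speak of the compounds shown alone.

In a functional assay on HL-60 cells (Homo sapiens) for cytotoxicity, read by MTT assay, with a stated time of 72 h (on this read-out higher numbers stand for weaker inhibition and lower numbers for stronger inhibition), compound 1 `O=S(=O)(c1ccc(F)cc1)c1nc2ccccc2nc1N1CCc2ccccc2C1` gives 4080 nM and compound 2 `O=S(=O)(c1ccccc1)c1nc2ccccc2nc1N1CCC(O)CC1` gives 2900 nM so these two stand within the usual scatter of each other. Compound 3 `O=S(=O)(c1ccc(F)cc1)c1nc2ccccc2nc1N1CCC(O)CC1` differs from compound 2 in one place: fluoro in place of hydrogen on an aromatic carbon with fluoro in place of hydrogen on an aromatic carbon, so phenyl becomes 4-fluorophenyl. Among the measured compounds shown here, no measured pair shows this change on its own, so nothing points to a large shift. The expected 1.0-fold higher number from compound 2 to compound 3 (0.01 log units; within the scatter) stays within the scatter, with no clear direction. The estimate for compound 3 is 3000 nM with an expected range from 1300 nM to 7000 nM around it.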

Compound 3, half-maximal inhibitory concentration: 1450 nM
Compound 3: middle estimate off by 2.1-fold (0.32 log units), on the high side; the measured number falls inside the stated range.
By their numbers in this assay, from the lowest: compounds 3, 2 and 1 (each within the scatter of the next, the first and the last beyond it).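

Swapping phenyl for 4-fluorophenyl gives a 2.0-fold lower number from compound 2 to compound 3 (0.30 log units; within the scatter) in this assay, so this first look at the change shows no shift that can be told apart from the scatter. Among the compounds shown here, with 4-fluorophenyl on both compounds, 4-hydroxypiperidin-1-yl in place of 1,2,3,4-tetrahydroisoquinolin-2-yl gives a 2.8-fold lower number from compound 1 to compound 3 (0.45 log units; beyond the scatter) and is the first step here to clear the scatter, though only modestly. Still open, going by these compounds, is whether chloro, methoxy or an amine on that same aromatic carbon would move the number further. No measurement at hand explains either step.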